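Removing a hydroxy from a shared thiazole-anilino core

The source may report more compounds than this note shows. Statements on the series, on what has been measured and on what is new or still open speak of the compounds shown alone.

Compound 1 `FC(F)(F)c1ccc(Nc2nc(-c3ccc(Cl)cc3)cs2)cc1`: 5900 nM
Compound 2 `COc1ccccc1Nc1nc(-c2ccc(Cl)cc2)cs1`: 22500 nM
Compound 3 `Oc1cccc(Nc2nc(-c3ccc(Cl)cc3)cs2)c1`: 5600 nM

All three measured compounds were tested in an assay on isolated protein for inhibition of Polyunsaturated fatty acid 5-lipoxygenase (Homo sapiens), with stated times of 15 min and 10 min; on this read-out higher numbers stand for weaker inhibition and lower numbers for stronger inhibition. They share one core and differ only in the group on the outer benzene ring. In this assay compound 3 gives 5600 nM; compound 1 gives 5900 nM, and the gap between these two lies within the scatter, so no order between them can be read. Compound 2 gives 22500 nM, a number that stands beyond the scatter above both of the others.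

Compound 4 `Clc1ccc(-c2csc(Nc3ccccc3)n2)cc1` has not yet been measured. It differs from compound 3 in one place: hydrogen in place of hydroxy on an aromatic carbon. Going by the values given here, no measured pair among the three compounds shows this exact change, so there is no direct step to lean on. What the data do show is that a hydroxy in this place and a trifluoromethyl in compound 1 give numbers within the scatter of each other, while the methoxy of compound 2 gives a clearly higher one.

With that in mind, the step of a 1.4-fold higher number from compound 3 to compound 4 (0.15 log units; within the scatter) is expected to be small, at most a modest rise in the number, and it may well fall within the scatter. Compound 4 is therefore estimated at 8000 nM, with a likely range from 3000 nM to 25000 nM.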

Compound 4, half-maximal inhibitory concentration: 5600 nM
The estimate for compound 4 lay 1.4-fold (0.15 log units) above the measured number; low and high end bracket the measured number.
By their numbers in this assay, from the lowest: compounds 3, 4 and 1 (each within the scatter of the next); then compound 2.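

In this assay, going by these compounds alone, the plain ring of compound 4 gives the series a reference point that the earlier compounds lacked, showing that the hydroxy on this aromatic carbon can be lost without any readable effect: hydrogen in place of hydroxy gives no change at the digits printed from compound 3 to compound 4 (within the scatter) in this test. Hydrogen in place of trifluoromethyl gives a 1.1-fold lower number from compound 1 to compound 4 (0.02 log units; within the scatter) as well, so neither group can be credited with a measurable gain over hydrogen. Hydrogen in place of methoxy is the only one of the three changes to move the number beyond the scatter, with a 4.0-fold lower number from compound 2 to compound 4 (0.60 log units; beyond the scatter) and thus a clear drop, which makes compound 2 the one that stands apart, with the methoxy costing inhibition rather than the other groups adding to it.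

On these data alone, the groups in compounds 1, 2 and 3 sit on different carbons of the outer ring, so it remains open whether methoxy would read the same where the hydroxy sits, and what an amine or a carboxylic acid would do there. Nothing available explains why methoxy stands apart from the other groups.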